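The source may hold more compounds than are shown below. What is called first, only, known or untested is meant among the compounds shown, and "the series" means these compounds.

In a functional assay on HL-60 cells (Homo sapiens) for cytotoxicity, read by WST assay, with a stated time of 48 h (a lower number here means that less compound is needed, a higher number that more compound is needed for the effect), compound 1 `O=C1OC[C@H](Cc2ccccc2)[C@H]1Cc1ccccc1OC(F)(F)F` gives 39000 nM and compound 2 `COCOc1ccccc1C[C@H]1C(=O)OC[C@@H]1Cc1ccccc1` gives 76000 nM while compound 3 `COc1cccc(C[C@H]2C(=O)OC[C@@H]2Cc2ccccc2)c1` gives 66000 nM and so stands within the scatter of both. Within the data shown here, the one measured step (a 1.9-fold higher number from compound 1 to compound 2 (0.29 log units; within the scatter)) swaps groups on an oxygen on an aromatic ring, so it bears only loosely on the next change. Compound 4 `O=C1OC[C@H](Cc2ccccc2)[C@H]1Cc1cccc(Cl)c1` has chloro in place of methoxy on an aromatic carbon, meta to a large group (chloro in place of methoxy on an aromatic carbon). No measured step covers this swap, and the three values give no reason to expect a step beyond the scatter in this assay in either direction. The expected step (a 1.3-fold lower number from compound 3 to compound 4 (0.12 log units; within the scatter)) is therefore small. For compound 4 the estimate is 50000 nM with an expected range from 22000 nM to 100000 nM in this series.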

Compound 4, half-maximal effective concentration: 36000 nM
Estimate against measurement, compound 4: 1.4-fold (0.14 log units) above, within the range that was stated.
By their numbers in this assay, from the lowest: compounds 4, 1, 3 and 2 (each within the scatter of the next, the first and the last beyond it).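

In this assay, among these compounds, chloro in place of methoxy on an aromatic carbon, meta to a large group, gives a 1.8-fold lower number from compound 3 to compound 4 (0.26 log units; within the scatter), the first measured step at a ring carbon rather than on an oxygen on an aromatic ring. At this place, a single chlorine and a methoxy therefore cannot be told apart in this assay, despite the loss of the hydrogen-bond acceptor counted for methoxy. No measurement bearing on the cause of this step is available.

Open, from the compounds shown here alone, is whether an amine or a carboxylic acid on this aromatic carbon would give a step beyond the scatter. Also open, going by these compounds, is whether any substituent here separates from the others.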